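The compounds below may be only part of what the source reports. "The series", "measured", "known", "first", "only" and "open" are said of these compounds alone.

Compound 3 `Cc1ccccc1C(=O)Nc1ccc(S(=O)(=O)NC2CCN(C(=O)C3CNC3)CC2)c2ccccc12` is the piece's starting point. Three close relatives of one core have been measured in an assay on L1.2 cells for binding affinity to C-C chemokine receptor type 8 (Homo sapiens); a lower number here means a stronger inhibitor, a higher number a weaker inhibitor. Compound 1 `Cc1ccccc1C(=O)Nc1ccc(S(=O)(=O)NC2CCN(C(=O)CO)CC2)c2ccccc12` gives 5.4 nM, compound 2 `Cc1ccccc1C(=O)Nc1ccc(S(=O)(=O)NC2CCN(C(=O)CCCN)CC2)c2ccccc12` gives 1.6 nM, and compound 3 gives 1.5 nM, the lowest of the three numbers, though compound 2 sits within the scatter of it (a 1.1-fold lower number from compound 2 to compound 3 (0.03 log units; within the scatter)). The two steps away from compound 1 were modest but real: a 3.4-fold lower number from compound 1 to compound 2 (0.53 log units; beyond the scatter) and a 3.6-fold lower number from compound 1 to compound 3 (0.56 log units; beyond the scatter).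

Compound 4 `Cc1ccccc1C(=O)Nc1ccc(S(=O)(=O)NC2CCN(C(=O)N(C)C)CC2)c2ccccc12` is the next step. The change is dimethylamino in place of azetidin-3-yl on a carbonyl carbon. For the measured compounds named here, no measured step mirrors this exchange, so the forecast leans on what the three numbers show: both the group in compound 2 and the group in compound 3 lowered the number relative to the hydroxy of compound 1, and compound 4 carries neither of them, nor the hydroxy. A rise in the number is therefore expected, of a modest size, roughly back toward where compound 1 stands, with the direction more certain than the size.

For compound 4 the estimate in this assay is 7 nM, with a likely range from 2.5 nM to 25 nM, a step of a 4.7-fold higher number from compound 3 to compound 4 (0.67 log units; beyond the scatter) that is expected rather than known.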

Compound 4, inhibition constant: 1.6 nM
The estimate for compound 4 lay 4.4-fold (0.64 log units) above the measured number; the whole stated range lies above it.
By their numbers in this assay, from the lowest: compounds 3, 2 and 4 (each within the scatter of the next); then compound 1.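

In this assay, the exchange of azetidin-3-yl for dimethylamino on the carbonyl carbon gives a 1.1-fold higher number from compound 3 to compound 4 (0.03 log units; within the scatter), and replacing 3-aminopropyl with dimethylamino gives no change at the digits printed from compound 2 to compound 4 (within the scatter), so compounds 2, 3 and 4 cannot be told apart here. At this position, therefore, neither the four-membered ring nor the hydrogen-bond donor of azetidin-3-yl is needed to hold this level, since dimethylamino has no ring and 0 hydrogen-bond donors. The three compounds now share one gap from compound 1, with dimethylamino in place of hydroxymethyl giving a 3.4-fold lower number from compound 1 to compound 4 (0.53 log units; beyond the scatter), which leaves compound 1 as the only one apart among these four, and no information on the cause of that gap is available.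

Going by these compounds, it remains open whether a plain methyl or a chain ending in a carboxylic acid on the same carbonyl carbon would sit with compounds 2, 3 and 4 or with compound 1. Also open, on these data alone, is whether a larger group on the carbonyl, such as a morpholine ring or a longer chain, would keep this level in this assay.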